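The source may report more compounds than this note shows. Statements on the series, on what has been measured and on what is new or still open speak of the compounds shown alone.

Within the data shown here, in a physicochemical assay for lipophilicity (a higher number here means a more lipophilic compound, a lower number a more polar compound), compound 1 `COc1c(OC)c(OC(C)=O)c2ccccc2c1OC(C)=O` gives 2.39 and compound 2 `COc1c(OC)c(OC(C)=O)c2cc(C)ccc2c1OC(C)=O` gives 2.86 as the higher of the two numbers so far. Among the measured compounds shown here, the one measured change, a methyl in place of hydrogen on an aromatic carbon, gives a number 0.47 log units higher from compound 1 to compound 2 (beyond the scatter) and so far stands alone.

Compound 3 `COc1c(OC)c(OC(C)=O)c2cc(C)c(C)cc2c1OC(C)=O` is still unmeasured and differs from compound 2 by methyl in place of hydrogen on an aromatic carbon with the incoming methyl ortho to a methyl group. For the measured compounds named here, this is the same kind of change as the measured one, so that single step is the only guide, and it is thin support. The data do not yet show what a methyl does when it enters ortho to a methyl group, so the range stays fairly wide.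

Going by a number 0.47 log units higher from compound 1 to compound 2 (beyond the scatter) as the precedent, a modest step upward in this assay is expected, of about the same size or a little smaller. The expected step is a number 0.44 log units higher from compound 2 to compound 3 (beyond the scatter) on this estimate. For compound 3 the estimated value is 3.3 with an expected range from 3 to 3.6 around that middle.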

Compound 3, partition coefficient: 3.14
Estimate against measurement, compound 3: 0.16 log units above; measured number inside the range.
By their numbers in this assay, from the lowest: compound 1; then compounds 2 and 3 (each within the scatter of the next).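

Working notes on the series. In this assay the methyl entering ortho to a methyl group gives a number 0.28 log units higher from compound 2 to compound 3 (within the scatter) and thus stands apart from the earlier replacement of hydrogen by methyl, which gave a number 0.47 log units higher from compound 1 to compound 2 (beyond the scatter) on the same shared core. The same kind of change therefore does not repeat as a step beyond the scatter at this position, and compounds 2 and 3 cannot be put in order on these numbers, so one methyl step cannot be treated as a fixed increment for the series. Nothing available explains why the two steps read differently.

From the compounds shown here alone, with only these two steps, it remains open whether the outcome for compound 3 belongs to the neighbouring methyl group, to this position on the ring, or simply to the scatter of the measurement. Also open is how this assay would respond to a different group at this same aromatic carbon, such as an ethyl group, an amine or a carboxylic acid, since every step shown so far puts in a methyl.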